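The source may report more compounds than this note shows. Statements on the series, on what has been measured and on what is new or still open speak of the compounds shown alone.

Compound 1 `Cc1ccc(-n2nccn2)c(C(=O)N2C[C@@H]3CN(c4nc(C)c(C)c(C)n4)C[C@@H]3C2)c1` sits at the limit of a functional assay on HEK293 cells for antagonist activity at Orexin/Hypocretin receptor type 1 (Homo sapiens), read by FLIPR and calcium flux, with a stated time of 60 min (a higher number here means a weaker inhibitor, a lower number a stronger inhibitor), where compound 1 gives > 10000 nM, a limit and not a number (the limit of > 10000 nM in this assay, at which 1 of the 2 values shown sits). Compound 2 `Cc1ccc(-n2nccn2)c(C(=O)N2C[C@@H]3CN(c4nc(-c5cccc(Cl)c5)co4)C[C@@H]3C2)c1` carries a different group on the same ring nitrogen, and in this assay compound 2 gives 1010 nM, a measured value rather than a limit. Compound 3 `Cc1ccc(-n2nccn2)c(C(=O)N2C[C@@H]3CN(c4ncc5cc(F)ccc5n4)C[C@@H]3C2)c1` is the unmeasured member of the set; it differs from compound 1 by 6-fluoroquinazolin-2-yl in place of 4,5,6-trimethylpyrimidin-2-yl on an amine nitrogen in a ring. Because compound 1 stands at > 10000 nM, only a move toward stronger inhibition can be read from a measurement of compound 3, and such a move is expected to be beyond the usual scatter. The estimated step from compound 1 to compound 3 is an at least 50-fold lower number from compound 1 to compound 3 (1.69 log units; beyond the scatter). In this assay compound 3 is therefore expected to come in near 200 nM, within a range from 40 nM to 1500 nM.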

Compound 3, half-maximal inhibitory concentration: 216 nM
Compound 3: the middle estimate sits 1.1-fold (0.03 log units) below what was measured, and the stated range covers the measured number.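

In this assay, the group on the amine nitrogen in a ring of the shared core proves decisive: 6-fluoroquinazolin-2-yl in place of 4,5,6-trimethylpyrimidin-2-yl gives an at least 46-fold lower number from compound 1 to compound 3 (1.66 log units; beyond the scatter). Compound 1 gives > 10000 nM, which is a limit of the assay and not a number. The true size of the step therefore remains unknown, and the printed size is only a minimum, because one end of it is that limit: the limit of > 10000 nM in this assay, at which 1 of the 3 values shown sits.

The compounds shown do not separate what the fluorine contributes from what the carbon-only aromatic ring contributes, nor from the loss of the methyl groups, as these all change together in this one step. As far as these compounds go, it also remains open how the inhibition would respond to an unsubstituted quinazolin-2-yl, or to a methoxy group or an amine in place of the fluorine.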